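The source may hold more compounds than are shown below. What is called first, only, known or untested is meant among the compounds shown, and "the series" means these compounds.

In an assay on isolated protein for activation of Nicotinamide phosphoribosyltransferase (Homo sapiens) (on this read-out lower numbers stand for an effect already at smaller amounts and higher numbers for an effect only at larger amounts of compound), two compounds have been examined so far. Compound 1, with the structure `CCOC(=O)c1ccc(N(C)C(=O)NCc2ccncc2)cc1`, gives in this assay only a limit, > 100000 nM. Compound 2, with the structure `CNS(=O)(=O)c1ccc(NC(=O)NCc2ccncc2)cc1`, gives in this assay 3230 nM. Among the compounds with values here, compound 2 thus carries the only number among the two results reported, the other result being a limit (the limit of > 100000 nM in this assay, at which 1 of the 2 values shown sits), so there is no measured step against which its position could be judged.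

Compound 3, with the structure `CCN(CC)S(=O)(=O)c1ccc(NC(=O)NCc2ccncc2)cc1`, has not yet been tested in this assay. It differs from compound 2 in one place: diethylamino in place of methylamino on a sulfonyl sulfur. Compound 1 and compound 2 differ in more than one place, so no step between measured compounds describes a change of this kind, and no direction for the effect of enlarging the sulfonamide substituent can be taken from the data shown.

With nothing to lean on beyond the result of compound 2, the step from compound 2 to compound 3 is expected to stay close to nothing, a 1.1-fold higher number from compound 2 to compound 3 (0.03 log units; within the scatter), with a wide margin either way. Compound 3 is accordingly estimated to reach in this assay about 3500 nM, most likely somewhere between 700 nM and 18000 nM.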

Compound 3, half-maximal effective concentration: 384 nM
Compound 3: middle estimate off by 9.1-fold (0.96 log units), on the high side; measured number below the stated range.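

Compound 2 had stood alone, but the sulfonyl sulfur now proves to be a place where the substituent matters: putting diethylamino in place of methylamino gives an 8.4-fold lower number from compound 2 to compound 3 (0.92 log units; beyond the scatter) in this assay. The larger group is therefore accepted here, and since diethylamino brings no hydrogen-bond donor where methylamino brought one, a donor at this place is not needed for a measurable result in this pair. Nothing shown gives a measured reason for the size of this step.

Within the data shown here, the single change adds carbon atoms and removes the donor at the same time, so the pair cannot say which of the two goes with the lower number, and ethylamino, which keeps the donor, or dimethylamino, which lacks it with fewer carbon atoms, would be needed to pull them apart. As far as these compounds go, it also remains open whether the trend continues to longer chains such as dipropylamino, or holds when the two ethyl groups are tied into a ring such as piperidine or morpholine.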